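Acetyl replaced by dimethylpyrrolyl on the aromatic carbon

This account rests on a few compounds, and the source may have more. Where it says the series, first, only, none or still open, it means among the compounds named here.

Measured so far in a functional assay (aorta) with Rattus norvegicus as the target; a lower number here means a less potent compound, a higher number a more potent compound, by a factor of ten per unit of this negative logarithm:
compound 1 `CC1(C)C=C(n2ccccc2=O)c2ccccc2O1` gives 5.43
compound 2 `CC(=O)c1ccc2c(c1)C(n1ccccc1=O)=CC(C)(C)O2` gives 7.37
compound 3 `CC1(C)C=C(n2ccccc2=O)c2cc(C(=O)c3ccccc3F)ccc2O1` gives 7.08

Compound 2 stands highest of the three numbers. Its nearest neighbour is set by a number 0.29 log units lower from compound 2 to compound 3 (within the scatter), the widest gap by a number 1.94 log units higher from compound 1 to compound 2 (beyond the scatter).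

Compound 4 `Cc1ccc(C)n1-c1ccc2c(c1)C(n1ccccc1=O)=CC(C)(C)O2` differs from compound 2 in one place: 2,5-dimethyl-1H-pyrrol-1-yl in place of acetyl on an aromatic carbon.

Within the data shown here, two measured steps bear on the same aromatic carbon: a number 1.94 log units higher from compound 1 to compound 2 (beyond the scatter) and a number 1.65 log units higher from compound 1 to compound 3 (beyond the scatter), both large and both gained by adding a carbonyl-bearing group in place of hydrogen. The third step, a number 0.29 log units lower from compound 2 to compound 3 (within the scatter), shows that what sits on the carbonyl carbon hardly matters. Among the measured compounds shown here, no measured step removes the carbonyl itself or puts a ring directly on this carbon, so the data do not say whether the gain survives that exchange. A drop of modest size in this assay is expected, with wide uncertainty.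

Compound 4 is estimated at 6.9, between 5.9 and 7.8; the expected step is a number 0.47 log units lower from compound 2 to compound 4 (beyond the scatter).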

Compound 4, logarithm of the reciprocal of the active concentration, log(1/C): 7.27
The estimate for compound 4 lay 0.37 log units below the measured number; measured number inside the range.
By their numbers in this assay, from the lowest: compound 1; then compounds 3, 4 and 2 (each within the scatter of the next).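

In this assay, a carbonyl is not required at this aromatic carbon: with 2,5-dimethyl-1H-pyrrol-1-yl attached directly through its ring, the series shows a number 0.10 log units lower from compound 2 to compound 4 (within the scatter) against acetyl and a number 0.19 log units higher from compound 3 to compound 4 (within the scatter) against (2-fluorophenyl)carbonyl. The gain over hydrogen also holds without the carbonyl, with a number 1.84 log units higher from compound 1 to compound 4 (beyond the scatter), so all three groups shown at this carbon give a large step from compound 1, and none of the three goes against this. No evidence at hand bears on this result.

On these data alone, whether an amine, a carboxylic acid or a longer alkyl chain at the same carbon would keep this gain remains open. Also open, as far as these compounds go, is whether an unsubstituted pyrrol-1-yl group would match compound 4, which would show whether the two methyl groups are needed.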